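Dihydropyridine diesters on a shared core: ester size

This account rests on a few compounds, and the source may have more. Where it says the series, first, only, none or still open, it means among the compounds named here.

Measured so far:
- compound 1 `CC1=C(C(=O)OC(C)(C)C)C(c2csc(-c3ccc(Cl)cc3)n2)C(C(=O)OC(C)(C)C)=C(C)N1` — 21000 nM
- compound 2 `CC1=C(C(=O)OC2CCCC2)C(c2csc(-c3ccc(Cl)cc3)n2)C(C(=O)OC2CCCC2)=C(C)N1` — 19000 nM
- compound 3 `CC1=C(C(=O)OC2CCCCC2)C(c2csc(-c3ccc(Cl)cc3)n2)C(C(=O)OC2CCCCC2)=C(C)N1` — 11000 nM

All three compounds share one core and differ only in the two ester groups. In an assay on isolated protein for antagonist activity at Voltage-dependent L-type calcium channel subunit alpha-1C (Cavia porcellus), with a stated time of 15 min (a higher number here means a weaker inhibitor, a lower number a stronger inhibitor), compound 1 gives 21000 nM, the highest of the three numbers. Its nearest neighbour is compound 2, whose value in this assay sits within the scatter of that of compound 1; compound 3 is the furthest of the three, and its value also sits within the scatter. No ordering of the three can therefore be read from these numbers.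

Compound 4 `COC(=O)C1=C(C)NC(C)=C(C(=O)OC(C)(C)C)C1c1csc(-c2ccc(Cl)cc2)n1` has not yet been measured in this assay. It differs from compound 1 in one place: methyl in place of tert-butyl on an oxygen next to a carbonyl group. One of the two ester groups keeps its tert-butyl, the other carries a methyl.

Among the compounds with values here, no step between measured compounds covers this change, so the expectation rests on the spread of the three values alone, which is narrow. A step of the kind a 1.4-fold lower number from compound 1 to compound 4 (0.15 log units; within the scatter) is expected for compound 4, that is, no change beyond the scatter in either direction. Compound 4 is estimated at 15000 nM in this assay, with a range from 5000 nM to 45000 nM.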

Compound 4, half-maximal inhibitory concentration: 46000 nM
Compound 4: middle estimate off by 3.1-fold (0.49 log units), on the low side; measured number above the stated range.
By their numbers in this assay, from the lowest: compounds 3, 2 and 1 (each within the scatter of the next); then compound 4.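

Methyl in place of tert-butyl on an oxygen next to a carbonyl group gives, in this assay, a 2.2-fold higher number from compound 1 to compound 4 (0.34 log units; beyond the scatter) and so yields the first readable change in the series, a modest weakening. The earlier compounds shown here differ in both ester groups at once and their values lie within the scatter of each other, so they could not show that the group on this oxygen matters; this single-place pair shows that it does, with one ester keeping its tert-butyl. This remains one pair, which sets a direction for this swap only and no trend with the size of the ester group, and no measurement shown here offers a reason for the step.

On these data alone, it remains open whether ethyl or isopropyl on the same oxygen would give a value nearer that of the tert-butyl ester or that of the methyl ester. As far as these compounds go, it is equally open how the series would respond to methyl esters on both sides, or to a carboxylic acid or an amide in place of one ester.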